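A Phenyl Substituent Swap and Its Expected Cost

A few compounds are considered here, and "the series" means these few. Any claim that something is new, unique, unknown or untested is made for them only; others in the source may bear on it.

Compound 2 `CC1CC/C(=N\Nc2ccccc2F)c2ncc(C(=O)O)c(=O)n21` gives 1200 nM in a functional assay (mast cells) for inhibition, with Rattus norvegicus as the target; a lower number here means that less compound is needed, a higher number that more compound is needed for the effect.
Compound 3 `C[C@@H]1CC/C(=N\Nc2ccc(O)cc2)c2ncc(C(=O)O)c(=O)n21` gives 15600 nM in this assay.
Compound 1 `CCOC(=O)c1cnc2n(c1=O)C(C)CC/C2=N\Nc1ccccc1C(=O)O` gives 100000 nM in this assay.

Among these three, compound 2 has the lowest number in this assay. Compound 3 is the nearest to it, and its higher number lies beyond the scatter; compound 1 is the furthest, also beyond the scatter. For the measured compounds named here, no pair of these measured compounds differs in only one place, so no measured step is available as a guide.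

Compound 4 `Cc1ccc(N/N=C2\CCC(C)n3c2ncc(C(=O)O)c3=O)cc1` differs from compound 2 in one place: 4-methylphenyl in place of 2-fluorophenyl on an amine nitrogen. Compound 3, which carries 4-hydroxyphenyl in the corresponding position, gives 15600 nM, a higher number than compound 2, and that is the only hint in the set. The step of a 2.5-fold higher number from compound 2 to compound 4 (0.40 log units; beyond the scatter) is therefore expected to go upward, but only modestly, and it may fall within the scatter. Compound 4 is estimated at 3000 nM in this assay, with a range from 800 nM to 12000 nM.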

Compound 4, half-maximal effective concentration: 280 nM
Compound 4: the middle estimate sits 11-fold (1.03 log units) above what was measured; measured number outside the range, below it.
By their numbers in this assay, from the lowest: compound 4; then compound 2; then compound 3; then compound 1.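

In this assay, for the compounds shown here, replacing 2-fluorophenyl with 4-methylphenyl on the amine nitrogen gives a 4.3-fold lower number from compound 2 to compound 4 (0.63 log units; beyond the scatter), the first measured step in this set at this place. It shows that the aryl group held there can shift the number beyond the scatter, and that this change moves it downward, leaving compound 4 with the lowest number of the four compounds. Nothing available bears on the reason for this shift.

The step alters both the ring substituent and where it sits, so the compounds shown cannot separate these two parts of the change. From the compounds shown here alone, how an unsubstituted phenyl, or a phenyl ring carrying a methoxy group or a chlorine, would read at this place also remains open.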